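Substituent walk on the fused ring of the urea series

A few compounds are considered here, and "the series" means these few. Any claim that something is new, unique, unknown or untested is made for them only; others in the source may bear on it.

The three measured compounds share one core: compound 1 `O=C(Nc1ccc(-n2ncc3c(Br)cccc32)cc1)Nc1ccc(Cl)c(C(F)(F)F)c1`, compound 2 `Cc1cccc2c1cnn2-c1ccc(NC(=O)Nc2ccc(Cl)c(C(F)(F)F)c2)cc1` and compound 3 `O=C(Nc1ccc(-n2ncc3ccccc32)cc1)Nc1ccc(Cl)c(C(F)(F)F)c1`. In a functional assay on MDA-MB-231 cells (Homo sapiens) for cytotoxicity, read by MTT assay, with a stated time of 72 h (on this read-out higher numbers stand for weaker inhibition and lower numbers for stronger inhibition), compound 1 gives 7700 nM, compound 2 gives 2300 nM and compound 3 gives 5000 nM. On these numbers compound 3 stands second highest; its nearest neighbour is compound 1, within the scatter, and the one furthest from it is compound 2.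

Compound 4 `COc1cccc2c1cnn2-c1ccc(NC(=O)Nc2ccc(Cl)c(C(F)(F)F)c2)cc1` carries methoxy in place of hydrogen on an aromatic carbon, on an aromatic carbon of a six-membered aromatic ring of carbon only, part of a fused system of two rings, ortho to a fused ring and meta to a fused ring. Among the measured compounds shown here, two steps touch the same position. Hydrogen in place of methyl gave a modest rise, a 2.2-fold higher number from compound 2 to compound 3 (0.34 log units; beyond the scatter), so methyl sits at a lower number than hydrogen. Hydrogen in place of bromo gave a 1.5-fold lower number from compound 1 to compound 3 (0.19 log units; within the scatter), which is within the scatter. A methoxy at that position is therefore expected to move this assay only modestly, toward a lower number, a 1.6-fold lower number from compound 3 to compound 4 (0.19 log units; within the scatter). Compound 4 is estimated at 3200 nM, within 1500 nM to 7000 nM.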

Compound 4, half-maximal inhibitory concentration: 1200 nM
Estimate against measurement, compound 4: 2.7-fold (0.43 log units) above, and the stated range ends above it.
By their numbers in this assay, from the lowest: compounds 4 and 2 (each within the scatter of the next); then compounds 3 and 1 (each within the scatter of the next).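

Methoxy in place of hydrogen on this aromatic carbon is a step beyond the scatter in this assay (a 4.2-fold lower number from compound 3 to compound 4 (0.62 log units; beyond the scatter)), and so is methoxy in place of bromo (a 6.4-fold lower number from compound 1 to compound 4 (0.81 log units; beyond the scatter)). Methoxy in place of methyl stays within the scatter (a 1.9-fold lower number from compound 2 to compound 4 (0.28 log units; within the scatter)), so methoxy and methyl cannot be told apart here, and methoxy is a second group, after methyl, at a lower number than bromo. No measurement on hand gives a cause for these steps.

Open, from the compounds shown here alone, is whether an amine, a hydroxyl or a longer chain such as ethoxy on this aromatic carbon would fall with methoxy and methyl or with hydrogen and bromo. Also open, going by these compounds, is whether these steps hold on any other cell line.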